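The source may report more compounds than this note shows. Statements on the series, on what has been measured and on what is new or still open speak of the compounds shown alone.

Measured in a functional assay on HepG2 cells (Homo sapiens) for antiproliferative activity, read by MTT assay, with a stated time of 24 h; a lower number here means a stronger inhibitor, a higher number a weaker inhibitor:
- compound 1 `O=[N+]([O-])c1ccc(CSc2nnc(-c3ccc4c(c3)OCCO4)n2-c2ccccc2)cc1`: 13800 nM
- compound 2 `COc1cccc(CSc2nnc(-c3ccc4c(c3)OCCO4)n2-c2ccccc2)c1`: 35100 nM
- compound 3 `Fc1ccc(CSc2nnc(-c3ccc4c(c3)OCCO4)n2-c2ccccc2)cc1`: 1020 nM

Compound 3 has the lowest number of the three, so it is the strongest inhibitor so far. Compound 4 `Brc1cccc(CSc2nnc(-c3ccc4c(c3)OCCO4)n2-c2ccccc2)c1` has not yet been measured. It keeps the shared core of compound 3 and carries 3-bromophenyl in place of 4-fluorophenyl on a saturated chain carbon bound to a sulfur.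

For the measured compounds named here, two measured steps bear on this change, and both are large: a 14-fold lower number from compound 1 to compound 3 (1.13 log units; beyond the scatter), and a 34-fold lower number from compound 2 to compound 3 (1.54 log units; beyond the scatter). The second is the closer guide, since compound 2 also carries a 3-substituted phenyl. In these three compounds, the number is higher whenever 4-fluorophenyl is absent, although neither comparison involves a bromo group. A clear rise in this assay is therefore expected, though its size is uncertain. The expected change is an 8.8-fold higher number from compound 3 to compound 4 (0.95 log units; beyond the scatter). Compound 4 is estimated at 9000 nM, with an expected range from 2000 nM to 35000 nM.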

Compound 4, half-maximal inhibitory concentration: 5210 nM
The estimate for compound 4 lay 1.7-fold (0.24 log units) above the measured number; measured number inside the range.
By their numbers in this assay, from the lowest: compound 3; then compound 4; then compound 1; then compound 2.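

In this assay, for the compounds shown here, 3-bromophenyl in place of 4-fluorophenyl on the saturated chain carbon bound to a sulfur gives a 5.1-fold higher number from compound 3 to compound 4 (0.71 log units; beyond the scatter), so losing 4-fluorophenyl costs less here than in the earlier comparisons. Having a 3-substituted phenyl does not by itself fix the number, since bromo in place of methoxy gives a 6.7-fold lower number from compound 2 to compound 4 (0.83 log units; beyond the scatter), and 3-bromophenyl in place of 4-nitrophenyl gives a 2.6-fold lower number from compound 1 to compound 4 (0.42 log units; beyond the scatter). No measurement shown here explains these differences.

Compounds 3 and 4 differ in both the halogen and its place on the ring, so their step cannot assign the change to either one alone. A 4-bromophenyl or 3-fluorophenyl group would separate the two, while an aminophenyl group would test a different kind of substituent.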